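This account rests on a few compounds, and the source may have more. Where it says the series, first, only, none or still open, it means among the compounds named here.

Compound 1 `O=C(Nc1cc(Sc2ncn[nH]2)c(O)c2ccccc12)c1cccc([N+](=O)[O-])c1` gives 29.3% in an assay on isolated protein for inhibition of RAC-alpha serine/threonine-protein kinase (Homo sapiens), read by fluorescence, with a stated time of 30 min, tested at 10 uM; a lower number here means less inhibition, a higher number more inhibition at the concentration tested (going by the name of the read-out). Compound 2 `O=C(/C=C/c1ccccc1)Nc1cc(Sc2ncn[nH]2)c(O)c2ccccc12` gives 26.2%. Compound 3 `COc1ccc(C(=O)Nc2cc(Sc3ncn[nH]3)c(O)c3ccccc23)cc1` gives 30.8%.

All three share one core and differ only in the group on the carbonyl carbon, and their numbers sit within the scatter of one another: a number 3.1 percentage points lower from compound 1 to compound 2 (within the scatter), a number 1.5 percentage points higher from compound 1 to compound 3 (within the scatter) and a number 4.6 percentage points higher from compound 2 to compound 3 (within the scatter) are each within the scatter, so compound 3 cannot be set apart from compound 1 or compound 2. Compound 4 `COc1cccc(C(=O)Nc2cc(Sc3ncn[nH]3)c(O)c3ccccc23)c1` has not yet been measured. (3-methoxyphenyl in place of 4-methoxyphenyl on a carbonyl carbon). Among the measured compounds shown here, the steps into compound 3 from compound 1 and compound 2 bear on this change, since each replaced the whole group on the carbonyl carbon without moving the number beyond the scatter; no measured step exchanges a 4-methoxyphenyl for a 3-methoxyphenyl. Compound 4 is therefore expected to stay within the scatter of compound 3, a step of a number 1.8 percentage points lower from compound 3 to compound 4 (within the scatter). Compound 4 is estimated at 29% in this assay, between 18% and 40%.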

Compound 4, a percentage reported as inhibition, at one concentration (the size of the read-out at that concentration, not a potency): 19.4%
The estimate for compound 4 lay 9.6 percentage points above the measured number; low and high end bracket the measured number.
By their numbers in this assay, from the lowest: compounds 4, 2, 1 and 3 (each within the scatter of the next, the first and the last beyond it).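

In this assay, among the compounds shown here, the exchange of 4-methoxyphenyl for 3-methoxyphenyl on a carbonyl carbon gives a number 11.4 percentage points lower from compound 3 to compound 4 (beyond the scatter) and is the first step at this place to pass the scatter, although the two groups have the same atoms. The steps of a number 6.8 percentage points lower from compound 2 to compound 4 (within the scatter) and a number 9.9 percentage points lower from compound 1 to compound 4 (within the scatter) stay within it, so compound 4 is set apart from compound 3 alone. No measured evidence bears on this difference. The compounds shown leave open whether an ethoxy or an amine in place of the methoxy on an aromatic carbon would give a number nearer that of compound 3 or compound 4.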